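Cytotoxicity of uracil ethers: dropping the chloro substituent

A few compounds are considered here, and "the series" means these few. Any claim that something is new, unique, unknown or untested is made for them only; others in the source may bear on it.

Two members of the series have a reading in an ADME assay on MT2 cells (Homo sapiens) for cytotoxicity, read by MTT assay; on this read-out lower numbers stand for higher toxicity in this test and higher numbers for lower toxicity in this test. Among the compounds with values here, compound 1 `O=c1ccn(CCOc2ccccc2Oc2cccc3ccccc23)c(=O)[nH]1` is the only one with a number: in this assay compound 1 gives 80000 nM. Compound 2 `N#Cc1ccc2c(Oc3ccc(Cl)cc3OCCn3ccc(=O)[nH]c3=O)cccc2c1` returns no number in this assay; for compound 2 the result is a limit, > 100000 nM. Within the data shown here, compound 2 thus stands at the limit of > 100000 nM in this assay, at which 1 of the 2 values shown sits, and no measured step connects it to compound 1, so the two readings show only that compound 1 carries a number and compound 2 does not.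

Compound 3 `N#Cc1ccc2c(Oc3ccccc3OCCn3ccc(=O)[nH]c3=O)cccc2c1` has not been run in this assay. It differs from compound 2 by hydrogen in place of chloro on an aromatic carbon. Among the measured compounds shown here, no measured pair mirrors this change, so the step from compound 2 to compound 3 in this assay is expected to stay within the scatter, with a number no higher from compound 2 to compound 3 (the limit leaves the size open) as the estimated shift, in no particular direction. Compound 3 is therefore estimated at 100000 nM, within 40000 nM to 250000 nM, and a limit reading rather than a number remains the likelier outcome.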

Compound 3, half-maximal cytotoxic concentration: > 100000 nM
Compound 3: only a limit was reported; the forecaster's own chance of this, stated with the estimate: 60%; the middle value lies on the limit itself.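

In this assay compound 3 gives > 100000 nM as a limit and not as a number. Cyano in place of hydrogen on an aromatic carbon provides the first readable step of the series, an at least 1.2-fold higher number from compound 1 to compound 3 (0.09 log units; that floor lies within the scatter) so no clear separation of the two compounds is established. The step with hydrogen in place of chloro cannot be read, as both of its ends are limits, and the reading with chloro gone stays at the limit: the limit of > 100000 nM in this assay, at which 2 of the 3 values shown sit.

The compounds shown leave open how far the two limit readings lie from the number of compound 1, and whether chloro on its own changes the reading at all. Also open, going by these compounds, is whether an amine or a carboxylic acid in place of the cyano would return a number in this assay and not a limit.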